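The source may report more compounds than this note shows. Statements on the series, on what has been measured and on what is new or still open speak of the compounds shown alone.

Compound 1 is `O=[N+]([O-])c1cccc(S(=O)(=O)Nc2ccc(Cl)cc2)c1` and compound 2 is `O=[N+]([O-])c1cccc(S(=O)(=O)Nc2ccc(F)cc2)c1`; the two differ by fluoro in place of chloro on an aromatic carbon. Compound 3 is `O=[N+]([O-])c1ccc(S(=O)(=O)Nc2ccc(Cl)cc2)cc1`, built from the same atoms as compound 1 but joined differently; the difference between the two cores is not broken down here. Compound 4 is `O=[N+]([O-])c1ccc(S(=O)(=O)Nc2ccc(F)cc2)cc1`, and it differs from compound 3 by fluoro in place of chloro on an aromatic carbon, the same change at the same kind of place that separates compound 1 from compound 2.

In an ADME assay, compound 1 gives 7.19. In this assay compound 2 gives 7.27, so that the step is a number 0.08 log units higher from compound 1 to compound 2 (within the scatter), and the two values cannot be told apart. In this assay compound 3 gives 6.24, the lowest of the three numbers; its nearest neighbour is compound 1, higher by an amount beyond the scatter, and compound 2 stands further still.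

Compound 4 has not yet been measured in this assay. Because the same change gave a number 0.08 log units higher from compound 1 to compound 2 (within the scatter), the expected step is a number 0.08 log units higher from compound 3 to compound 4 (within the scatter), again within the scatter. That rests on one pair only, so the estimate carries the uncertainty of a single precedent on a different core. Compound 4 is therefore estimated at 6.32, expected to fall between 6.05 and 6.6.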

Compound 4, acid dissociation constant: 6.45
Compound 4: the middle estimate sits 0.13 log units below what was measured, and the stated range covers the measured number.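

In this assay, fluoro in place of chloro on the core of compound 3 gives a small step, a number 0.21 log units higher from compound 3 to compound 4 (within the scatter), and the measured pair therefore behaves like the earlier pair on the other core. Set side by side, the two steps cannot be told apart, so within these four compounds the exchange carries from one core to the other without a measurable difference: the same change on two cores in this assay, a number 0.08 log units higher (within the scatter) from compound 1 to compound 2 and a number 0.21 log units higher (within the scatter) from compound 3 to compound 4, 0.13 log units apart, within the scatter of two such steps

This does not show that the exchange would stay this small on every core of the series, since it rests on just two pairs, both with the same two halogens at the same kind of place, and neither step lies beyond the scatter of repeated measurements.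

The compounds shown carry only chloro or fluoro on an aromatic carbon para to a large group, which leaves open how a methoxy group, a trifluoromethyl group or an amine at that place would read in this assay. As far as these compounds go, it also remains open whether the small step between chloro and fluoro would hold on a core with a nitrile or a carboxylic acid in place of the nitro group.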